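The compounds below may be only part of what the source reports. "The series", "measured", "known", "first", "only" and "open" are said of these compounds alone.

In a physicochemical assay for solubility (a higher number here means a more soluble compound, a lower number a less soluble compound), compound 1 `O=C(O)c1ccc(C(=O)/C(=C\c2ccc(F)c([N+](=O)[O-])c2)SCc2ccc(Cl)cc2Cl)cc1` gives < 1000 ug/mL as its reading, which is a limit and not a number. Compound 2 `O=C(O)c1ccc(C(=O)/C(=C\c2ccc(F)c([N+](=O)[O-])c2)Sc2ccc(Br)cc2)cc1` likewise gives < 1000 ug/mL as a limit, so it has no exact place on the scale. The record so far is the limit of < 1000 ug/mL in this assay, at which 2 of the 2 values shown sit, and nothing firmer. Among the compounds with values here, the one measured step, also a swap on the sulfur, is a step that the two limits leave unreadable from compound 1 to compound 2 and offers no size to carry over. Compound 3 `O=C(O)c1ccc(C(=O)/C(=C\c2ccc(F)c([N+](=O)[O-])c2)SCc2ccc(C(F)(F)F)cc2)cc1`, not yet measured, carries 4-(trifluoromethyl)benzyl in place of 4-bromophenyl on a sulfur, a change counted as 4-(trifluoromethyl)benzyl in place of 4-bromophenyl on a sulfur and of the same kind as that step. With no readable step behind it, no direction can be argued, and no shift beyond the usual scatter is expected. The expected change is a step that the limit leaves unreadable from compound 2 to compound 3 and rests on little. For compound 3 the estimate is 300 ug/mL with a range from 30 ug/mL to 1000 ug/mL and this assay may well report only a limit again.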

Compound 3, solubility: < 1000 ug/mL
Compound 3 ended at the assay's limit (the forecaster's own chance of this, stated with the estimate: 85%); the middle value is on the limit's open side.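

Within the data shown here, compound 3 gives only a limit, as compound 1 and compound 2 do, so no step among the three can be read. As far as these compounds go, what stays open is how soluble each compound really is, and whether any swap on the sulfur changes that.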